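One ring exchanged: from compound 3 to compound 4

This account rests on a few compounds, and the source may have more. Where it says the series, first, only, none or still open, it means among the compounds named here.

Measured so far in a physicochemical assay for solubility, measured as kinetic solubility; a higher number here means a more soluble compound, a lower number a less soluble compound:
- Compound 1 `O=C(Nc1cc(Oc2cccnc2)cc([N+](=O)[O-])c1)c1ccc(F)cc1`: < 1 ug/mL, a limit of the assay
- Compound 2 `O=C(Nc1cc(F)cc(Oc2cccnc2)c1)c1ccc(F)cc1`: 5.3 ug/mL
- Compound 3 `O=C(Nc1ccc(F)cc1)Nc1cc(F)cc(Oc2cccnc2)c1`: 1.1 ug/mL

Compound 3 gives 1.1 ug/mL, the lower of the two actual numbers, while compound 2 gives 5.3 ug/mL. Compound 1 reports only the limit < 1 ug/mL.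

The next compound is compound 4 `COc1ccc(NC(=O)Nc2cc(F)cc(Oc3cccnc3)c2)cn1`, with 6-methoxypyridin-3-yl in place of 4-fluorophenyl on an amide-type nitrogen.

Two measured steps give a scale for this change. They are a 4.8-fold lower number from compound 2 to compound 3 (0.68 log units; beyond the scatter) and an at least 5.3-fold higher number from compound 1 to compound 2 (0.72 log units; beyond the scatter), both beyond the scatter. Neither exchanges this ring, so they bear on it only indirectly. Compound 3 already stands at 1.1 ug/mL, the lower of the two actual numbers. The estimated step is a 2.3-fold higher number from compound 3 to compound 4 (0.36 log units; beyond the scatter), expected to be a modest rise in this assay and no larger than those two steps. For compound 4 the expected value is 2.5 ug/mL, with an estimated range of 1 ug/mL to 7 ug/mL.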

Compound 4, solubility: 28 ug/mL
Compound 4: middle estimate off by 11-fold (1.05 log units), on the low side, outside the stated range (above it).
By their numbers in this assay, from the lowest: compound 3; then compound 2; then compound 4. At a limit, below all of these: compound 1.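

The group on the amide-type nitrogen turns out to have a large hold on this assay: 6-methoxypyridin-3-yl in place of 4-fluorophenyl gives a 25-fold higher number from compound 3 to compound 4 (1.41 log units; beyond the scatter) and so outweighs in size the earlier change on the carbonyl carbon, a 4.8-fold lower number from compound 2 to compound 3 (0.68 log units; beyond the scatter) in the opposite direction. The entering group brings a ring with 1 hetero atom and 2 hydrogen-bond acceptors, where the leaving group has a ring of carbon only and 0 hydrogen-bond acceptors. No measurement at hand gives a reason for this rise.

The ring nitrogen and the methoxy group enter together here, which leaves their separate shares in the step open. Also open, going by these compounds, is how a plain pyridin-3-yl would compare, or a pyridine ring carrying a dimethylamino group in place of the methoxy.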